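A few compounds are considered here, and "the series" means these few. Any claim that something is new, unique, unknown or untested is made for them only; others in the source may bear on it.

Among the compounds with values here, only three compounds have been tested so far. In a functional assay on BXPC-3 cells (Homo sapiens) for antiproliferative activity, read by MTT assay, with a stated time of 24 h (a higher number here means a weaker inhibitor, a lower number a stronger inhibitor), compound 1 (`CCn1c(C(=O)N[C@H](C)C(=O)OC)ccc1C(CC)(CC)c1ccc(OCS(=O)(=O)c2ccccc2)c(C)c1`) gives > 50000 nM as its reading, which is a limit and not a number. Compound 2 (`CCn1c(C(=O)N[C@H](CC(=O)O)C(=O)O)ccc1C(CC)(CC)c1ccc(OCS(=O)(=O)c2ccccc2)c(C)c1`) gives > 50000 nM as its reading, again a limit. Within the data shown here, compound 3 (`CCN(CC)CCNC(=O)c1ccc(C(CC)(CC)c2ccc(OCSC)c(C)c2)n1CC`) is the only one with a true number, at 5130 nM in this assay as its reading.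

Compound 4 (`CCN(CC)CCNC(=O)c1ccc(C(CC)(CC)c2ccc(OCS(C)(=O)=O)c(C)c2)n1CC`) differs from compound 3 in one place: methylsulfonyl in place of methylsulfanyl on a saturated chain carbon bound to an oxygen on an aromatic ring. In short, methylsulfonyl replaces methylsulfanyl on a saturated chain carbon bound to an oxygen on an aromatic ring. Among the measured compounds shown here, the one measured step, a step that the two limits leave unreadable from compound 1 to compound 2, concerns a different group and gives no size, so no measured step bears on this change. For the measured compounds named here, the only anchor is compound 3 at 5130 nM as its reading, so no step beyond the usual scatter is expected in this assay, though a slight weakening is possible. The estimate means an expected 1.4-fold higher number from compound 3 to compound 4 (0.13 log units; within the scatter) in this direction. Compound 4 is expected at 7000 nM as a middle value, with an estimated range of 2000 nM to 25000 nM as its span.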

Compound 4, half-maximal inhibitory concentration: 33700 nM
Compound 4: middle estimate off by 4.8-fold (0.68 log units), on the low side; measured number above the stated range.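

In this assay, replacing methylsulfanyl with methylsulfonyl on a saturated chain carbon bound to an oxygen on an aromatic ring gives a 6.6-fold higher number from compound 3 to compound 4 (0.82 log units; beyond the scatter), so this one change is enough to weaken the compound clearly. Within the data shown here, this is the first step of readable size, since the step between the two earlier compounds cannot be read, and it shows that activity responds to what sits at this position. The weakening also moves the reading toward the upper limit of this assay, which is a limit and not a number: the limit of > 50000 nM in this assay, at which 2 of the 4 values shown sit.

This single pair sets no pattern and gives no reason for the loss. As far as these compounds go, it remains open how an amine, a carboxylic acid or a longer chain in place of methylsulfanyl on that carbon would read.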